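A few compounds are considered here, and "the series" means these few. Any claim that something is new, unique, unknown or untested is made for them only; others in the source may bear on it.

In a functional assay on CHO cells for activation of 5-hydroxytryptamine receptor 1D (Homo sapiens), read by GTPgammaS binding (a higher number here means a larger maximal response, a lower number a smaller maximal response), compound 1 `CN(Cc1ccsc1)C1CCN(CCCc2c[nH]c3ccc(-n4cnnc4)cc23)CC1` gives 93%. Compound 2 `CN(Cc1ccccc1)CC1CCN(CCCc2c[nH]c3ccc(-n4cnnc4)cc23)CC1` stands level with it: in this assay compound 2 gives 93%, and the step of no change at the digits printed from compound 1 to compound 2 (within the scatter) stayed within the scatter. Compound 3 `CC(C)=CCN(C)C1CCN(CCCc2c[nH]c3ccc(-n4cnnc4)cc23)CC1` differs from compound 2 by methyl(3-methylbut-2-en-1-yl)amino in place of (benzyl(methyl)amino)methyl on a saturated ring carbon. Within the data shown here, the only measured step bearing on this change is no change at the digits printed from compound 1 to compound 2 (within the scatter), which exchanged one amine group on the same saturated ring carbon without effect; the group entering here has no ring, so that step is only a rough guide. The expected outcome is therefore no change beyond the scatter, a number 3 percentage points lower from compound 2 to compound 3 (within the scatter). The estimate for compound 3 in this assay is 90%, from 75% to 100%.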

Compound 3, largest response reached (reported as efficacy), in percent of the reference or control that the assay uses: 115%
For compound 3 the middle estimate is 25 percentage points below the measured one; measured number outside the range, above it.
By their numbers in this assay, from the lowest: compounds 1 and 2 (each within the scatter of the next); then compound 3.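

In this assay replacing (benzyl(methyl)amino)methyl with methyl(3-methylbut-2-en-1-yl)amino gave a number 22 percentage points higher from compound 2 to compound 3 (beyond the scatter) and placing 2-methylprop-1-en-1-yl where thiophen-3-yl stood gave a number 22 percentage points higher from compound 1 to compound 3 (beyond the scatter) as well. Unlike the earlier exchange, this change on the saturated ring carbon moves the maximal response, and the entering group has no ring and one double bond outside aromatic rings. Nothing available here explains the rise. As far as these compounds go, it remains open whether the double bond matters, as a saturated 3-methylbutyl chain on the same amine nitrogen would show, and whether a shorter allyl chain would hold the response.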